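A Bromo-Fluoro Swap on a Weakly Antiproliferative Hydrazone

The source may report more compounds than this note shows. Statements on the series, on what has been measured and on what is new or still open speak of the compounds shown alone.

Measured so far:
compound 1 `Cn1c(=O)c(=O)n(C2CCCC2)c2nc(N/N=C/c3ccc(C(F)(F)F)cc3)ncc21`: 40600 nM
compound 2 `Cn1c(=O)c(=O)n(C2CCCC2)c2nc(N/N=C/c3cc(C(F)(F)F)c(O)c(C(F)(F)F)c3)ncc21`: 22900 nM

Both compounds were tested in a functional assay on A549 cells (Homo sapiens) for antiproliferative activity, read by MTT assay; on this read-out lower numbers stand for stronger inhibition and higher numbers for weaker inhibition. Compound 1 gives 40600 nM in this assay, and compound 2 gives 22900 nM. Compound 1 has the higher of the two numbers, but its gap to compound 2 lies within the usual scatter, so the two cannot be told apart on these data; both are weak.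

Compound 3 `Cn1c(=O)c(=O)n(C2CCCC2)c2nc(N/N=C/c3ccc(F)cc3Br)ncc21` has not yet been measured. Compared with compound 1 it carries 2-bromo-4-fluorophenyl in place of 4-(trifluoromethyl)phenyl on a carbon with a double bond to nitrogen. Among the measured compounds shown here, no pair of measured compounds differs in only one place, so there is no measured step to lean on for this change.

With both measured compounds weak and close together, compound 3 is expected to stay in the same weak region, and the step from compound 1 to compound 3 is expected to be a 1.2-fold lower number from compound 1 to compound 3 (0.06 log units; within the scatter), none beyond the scatter, with the direction uncertain. Compound 3 is therefore estimated at 35000 nM in this assay, with a range from 10000 nM to 100000 nM.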

Compound 3, half-maximal inhibitory concentration: 6590 nM
Compound 3: middle estimate off by 5.3-fold (0.73 log units), on the high side, and the stated range ends above it.
By their numbers in this assay, from the lowest: compound 3; then compounds 2 and 1 (each within the scatter of the next).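

In this assay, replacing 4-(trifluoromethyl)phenyl with 2-bromo-4-fluorophenyl on a carbon with a double bond to nitrogen gives a 6.2-fold lower number from compound 1 to compound 3 (0.79 log units; beyond the scatter) and is the only step shown that clearly exceeds the scatter. This shows that activity can respond to the group at this position, something compound 1 and compound 2 could not show, since their numbers cannot be told apart, although compound 3 at 6590 nM is still only a modest gain and not a strong result. No measurement shown here explains why this exchange lowers the number.

The change removes the trifluoromethyl group and adds both a bromine and a fluorine in a single step, so the compounds shown cannot tell whether the bromine, the fluorine or the loss of the trifluoromethyl group accounts for the step. Going by these compounds, it also remains open whether a chlorine, a methoxy group or an amine on this same ring would lower the number further or raise it again, and whether any such gain would appear in cells other than those used here.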